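The source may report more compounds than this note shows. Statements on the series, on what has been measured and on what is new or still open speak of the compounds shown alone.

The shared core of compound 1 `COc1cnc(-c2ccccn2)nc1C1CCCC1` carries a cyclopentyl group, and in a functional assay on RAW264.7 cells (Mus musculus), with a stated time of 3 days (a lower number here means a stronger inhibitor, a higher number a weaker inhibitor), compound 1 gives 1800 nM. Compound 3 `COc1cnc(-c2ccccn2)nc1NC1CCCC1` has cyclopentylamino in place of cyclopentyl on an aromatic carbon, and in this assay compound 3 gives 570 nM, so that a 3.2-fold lower number from compound 1 to compound 3 (0.50 log units; beyond the scatter). Compound 2 `COc1cnc(-c2ccccn2)nc1NCc1ccccc1Cl` gives 520 nM in this assay, the lowest of the three numbers; compound 3 stands within the scatter of it, while compound 1 stands beyond it.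

Compound 4 `COc1cnc(-c2ccccn2)nc1NCCCC(=O)O` differs from compound 2 in one place: 2-carboxyethyl in place of 2-chlorophenyl on a saturated chain carbon bound to a nitrogen on an aromatic ring. Among the compounds with values here, no measured step changes this position; the only measured step concerns the linker, and the two values of compound 2 and compound 3 show that a 2-chlorophenylmethyl and a cyclopentyl group on that nitrogen give numbers within the scatter of each other. A 2-carboxyethyl chain is not covered by anything measured, so a moderate move to a higher number is expected for compound 4, with wide uncertainty: a 2.9-fold higher number from compound 2 to compound 4 (0.46 log units; beyond the scatter), giving an estimate of 1500 nM for compound 4, between 400 nM and 6000 nM.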

Compound 4, half-maximal inhibitory concentration: > 10000 nM
Compound 4 was reported as a limit (the forecaster's own chance of this, stated with the estimate: 10%); middle value at least 6.6-fold (0.82 log units) away from the limit.
By their numbers in this assay, from the lowest: compounds 2 and 3 (each within the scatter of the next); then compound 1. At a limit, above all of these: compound 4.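

Compound 4 is reported only as a limit: the limit of > 10000 nM in this assay, at which 1 of the 4 values shown sits. The earlier compounds shown here left the group on this nitrogen looking undemanding, since compound 2 and compound 3 stand within the scatter of each other, but in this assay that no longer holds: 2-carboxyethyl in place of 2-chlorophenyl gives an at least 19-fold higher number from compound 2 to compound 4 (1.28 log units; beyond the scatter), and 3-carboxypropyl in place of cyclopentyl gives an at least 17-fold higher number from compound 3 to compound 4 (1.24 log units; beyond the scatter). The nitrogen linker alone therefore does not secure the lower numbers, since (3-carboxypropyl)amino in place of cyclopentyl on an aromatic carbon gives an at least 5.5-fold higher number from compound 1 to compound 4 (0.74 log units; beyond the scatter).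

The compounds shown leave open whether this loss belongs to the carboxylic acid itself or to the chain that carries it, a question that an ester, an amide, a primary amine or a plain alkyl chain at this place would address. Going by these compounds, the full size of each step also stays open, as each is bounded by that limit.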